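Notes on the step from compound 3 to compound 4

This account rests on a few compounds, and the source may have more. Where it says the series, first, only, none or still open, it means among the compounds named here.

Measured so far in a functional assay on the whole organism for inhibition, with Mus musculus as the target, with a stated time of 180 s; on this read-out higher numbers stand for an effect only at larger amounts of compound and lower numbers for an effect already at smaller amounts
- compound 1 `CC(C)N1CCN(CCN2CCC(c3cn(-c4ccc(F)cc4)c4cc(Cl)ccc34)CC2)C1=O` gives 2 umol/kg
- compound 2 `Cc1ccc2c(C3CCN(CCN4CCN(C(C)C)C4=O)CC3)cn(-c3ccccc3)c2c1` gives > 11 umol/kg (a limit)
- compound 3 `CNC(=O)N(C)CCN1CCC(c2cn(-c3ccc(F)cc3)c3cc(Cl)ccc23)CC1` gives > 23 umol/kg (a limit)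

For compound 3 the value > 23 umol/kg is only a limit and not a number. The step to compound 4 `CC(C)NC(=O)N(C)CCN1CCC(c2cn(-c3ccc(F)cc3)c3cc(Cl)ccc23)CC1` is isopropyl in place of methyl on an amide-type nitrogen. Within the data shown here, the one measured step bearing on it is an at least 11-fold higher number from compound 1 to compound 3 (1.06 log units; beyond the scatter) and it is large and beyond the scatter. Compound 4 lacks the ring of compound 1 yet regains an isopropyl, so a partial return towards a lower number is expected in this assay and smaller than that step. The expected step is an at least 1.9-fold lower number from compound 3 to compound 4 (0.28 log units; that floor lies within the scatter) and it starts from a limit. For compound 4 the estimated value is 12 umol/kg (expected range 3 umol/kg to 45 umol/kg).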

Compound 4, dose for half-maximal effect: > 21 umol/kg
Compound 4: a limit, no number; the forecaster's own chance of this, stated with the estimate: 45%; middle value at least 1.7-fold (0.24 log units) away from the limit.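

In this assay the change from 3-isopropyl-2-oxoimidazolidin-1-yl to (isopropylcarbamoyl)(methyl)amino is an at least 10-fold higher number from compound 1 to compound 4 (1.02 log units; beyond the scatter) and shows that an isopropyl on the amide-type nitrogen of the open chain does not restore the low number of compound 1. Compound 4 gives > 21 umol/kg in this assay and that is a limit. The step between compound 3 and compound 4 cannot be read: both values are limits.

Going by these compounds, whether isopropyl in place of methyl changes anything at this nitrogen stays open. Also open, on these data alone, is how a tert-butyl or a cyclohexyl there would read in this assay on this open chain.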